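Aryl amine swap on the potent bicyclic amine core

This account rests on a few compounds, and the source may have more. Where it says the series, first, only, none or still open, it means among the compounds named here.

Measured so far:
Compound 1, `Clc1cccc(Nc2cncc(N3CC4CC(C3)N4)c2)c1`: in an assay on cell membranes for displacement of a labelled ligand from Neuronal acetylcholine receptor; alpha4/beta2 (Rattus norvegicus) (a higher number here means a weaker inhibitor, a lower number a stronger inhibitor), compound 1 gives 0.124 nM.
Compound 2, `Clc1cccc(Nc2ccc(N3CC4CC(C3)N4)nn2)c1`: in this assay compound 2 gives 1540 nM.
Compound 3, `Fc1ccc(Nc2ccc(N3CC4CC(C3)N4)nn2)cc1`: in this assay compound 3 gives 868 nM.

Compound 1 gives the lowest number of the three and is the strongest inhibitor here; compounds 2 and 3, which share a core different from that of compound 1, sit far higher. Compound 4, `Cc1ccc(Nc2cncc(N3CC4CC(C3)N4)c2)cc1`, is not yet measured in this assay; it differs from compound 1 in one place: 4-methylphenyl in place of 3-chlorophenyl on a nitrogen on an aromatic ring. Among the compounds with values here, the one measured step touching the aryl group, a 1.8-fold lower number from compound 2 to compound 3 (0.25 log units; within the scatter), removes the same leaving group on the other core and stays within the scatter. Within the data shown here, no aryl step on the core of compound 1 is measured. A small step is therefore expected, a 3.2-fold higher number from compound 1 to compound 4 (0.51 log units; beyond the scatter), if anything toward a slightly higher number. Compound 4 is estimated at 0.4 nM, range 0.08 nM to 3 nM.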

Compound 4, inhibition constant: 0.148 nM
The estimate for compound 4 lay 2.7-fold (0.43 log units) above the measured number, and the stated range covers the measured number.
By their numbers in this assay, from the lowest: compounds 1 and 4 (each within the scatter of the next); then compounds 3 and 2 (each within the scatter of the next).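

On the core of compound 1, in this assay, replacing 3-chlorophenyl with 4-methylphenyl gives a 1.2-fold higher number from compound 1 to compound 4 (0.08 log units; within the scatter). Within the data shown here, this is the first aryl step read on this core, and it shows that a sub-nanomolar number can be held with either group at this position, on a nitrogen on an aromatic ring. Nothing available explains this result.

The step changes the substituent and its ring position together, so the two changes cannot be separated. On these data alone, whether a phenyl ring carrying a carboxylic acid or an amine keeps the number this low remains open.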